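Carbamoyl in place of methyl on the shared core

This account rests on a few compounds, and the source may have more. Where it says the series, first, only, none or still open, it means among the compounds named here.

In an assay on isolated protein for inhibition of Myeloperoxidase (Homo sapiens), read by ELISA, with a stated time of 5 min (on this read-out lower numbers stand for stronger inhibition and higher numbers for weaker inhibition), the three measured compounds offer a limit, an unquantified result and a single number. Compound 1 `CCCc1c[nH]c2ccc(F)cc12` reaches only a limit, > 100 nM, and stands at the limit of > 100 nM in this assay, at which 1 of the 3 values shown sits. Compound 2 `NCCCc1c[nH]c2ccc(C(=O)O)cc12` is recorded as "not active" (no number reported). Compound 3 `NC(=O)CCc1c[nH]c2c(F)cccc12`, which also carries a carbamoyl group at the end of its chain, gives 64 nM in this assay.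

Compound 4 `NC(=O)CCc1c[nH]c2ccc(F)cc12` has not yet been measured in this assay. It differs from compound 1 by carbamoyl in place of methyl on a saturated chain carbon, two bonds along the chain from an aromatic carbon. For the measured compounds named here, no measured step frames this change, and compound 1 supplies only a limit rather than a number. Going by the values given here, the one numbered value, from compound 3 at 64 nM, comes from a compound bearing the same carbamoyl-terminated chain, and that is the basis of the expectation here. The step of an at least 1.6-fold lower number from compound 1 to compound 4 (0.22 log units; that floor lies within the scatter) is expected to run toward stronger inhibition, beyond the usual scatter. Compound 4 is estimated at 60 nM, with a range from 15 nM to 250 nM.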

Compound 4, half-maximal inhibitory concentration: 34 nM
Estimate against measurement, compound 4: 1.8-fold (0.25 log units) above, and the stated range covers the measured number.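

In this assay, carbamoyl in place of methyl on a saturated chain carbon, two bonds along the chain from an aromatic carbon, now has a step of its own, an at least 2.9-fold lower number from compound 1 to compound 4 (0.46 log units; beyond the scatter), and it runs toward stronger inhibition. For the compounds shown here, the earlier compounds offered no such step, so this is the first direct sign that this position responds to this change. Compound 1 remains a limit, > 100 nM, so the step gives only a floor and not its full size: the limit of > 100 nM in this assay, at which 1 of the 4 values shown sits.

Going by these compounds, it remains open whether the carbamoyl group itself is needed at the end of this chain, or whether a nitrile or a methyl ester there would serve as well. On these data alone, it is also open how a longer chain ending in carbamoyl would compare with compound 4 at 34 nM in this assay.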